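Dropping a Methyl from the Aryl Urea of Compound 1

A few compounds are considered here, and "the series" means these few. Any claim that something is new, unique, unknown or untested is made for them only; others in the source may bear on it.

Compound 1 `Cc1ccc(NC(=O)Nc2nc(Nc3ccccc3)cc(Sc3c[nH]c4ccccc34)n2)cc1` holds the second highest of three numbers in a functional assay on PC-3 cells (Homo sapiens) for inhibition, with a stated time of 72 h (on this read-out lower numbers stand for stronger inhibition and higher numbers for weaker inhibition), where compound 1 gives 18500 nM. Compound 3 `COc1ccc(NC(=O)Nc2nc(Nc3cc(OC)cc(OC)c3)cc(Sc3c[nH]c4ccccc34)n2)cc1` gives 15100 nM, a value within the scatter of compound 1, while compound 2 `O=C(Nc1ccccc1)Nc1nc(Sc2c[nH]c3ccccc23)cc(N2CCN(Cc3ccccc3)CC2)n1` gives 42500 nM, a gap beyond the scatter. Compound 4 `O=C(Nc1ccccc1)Nc1nc(Nc2ccccc2)cc(Sc2c[nH]c3ccccc23)n1` has not yet been measured in this assay. It differs from compound 1 by hydrogen in place of methyl on an aromatic carbon. Among the compounds with values here, no step between measured compounds carries this change, so nothing measured points the way. Losing a single methyl para to a large group is expected to move this assay little, and the step of a 1.1-fold higher number from compound 1 to compound 4 (0.03 log units; within the scatter) is expected to stay within the scatter. Compound 4 is therefore estimated at 20000 nM, within a range from 8000 nM to 50000 nM.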

Compound 4, half-maximal inhibitory concentration: 26400 nM
The estimate for compound 4 lay 1.3-fold (0.12 log units) below the measured number, within the range that was stated.
By their numbers in this assay, from the lowest: compounds 3, 1, 4 and 2 (each within the scatter of the next, the first and the last beyond it).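

Going from 4-methylphenyl to phenyl gives a 1.4-fold higher number from compound 1 to compound 4 (0.15 log units; within the scatter) in this assay and so offers the first direct reading at this position. On this single pair, the methyl para to a large group can give way to hydrogen without a shift beyond the scatter. Nothing measured here accounts for the step.

Open, going by these compounds, is whether an amine, a carboxylic acid or a longer chain at this position would move the number beyond the scatter. Also open, on these data alone, is whether the same change would read alike with the other groups of compound 3 in place.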